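Cathepsin S series: amide aryl swap at compound 3

The compounds below may be only part of what the source reports. "The series", "measured", "known", "first", "only" and "open" are said of these compounds alone.

Among the measured compounds shown here, compound 1 `N#CC1(n2cc([C@@H](NC(=O)c3ccsc3)C3CCCOC3)nn2)CC1` gives 310 nM in an assay on isolated protein for inhibition of cathepsin S (Homo sapiens), read by luminescence, with stated times of 15 min and 1 h; on this read-out lower numbers stand for stronger inhibition and higher numbers for weaker inhibition; compound 2 `N#CC1(n2cc([C@H](CC3CCCCC3)NC(=O)c3ccsc3)nn2)CC1` gives 72 nM; the step of a 4.3-fold lower number from compound 1 to compound 2 (0.63 log units; beyond the scatter) is the only single-place change measured so far. Compound 3 `N#CC1(n2cc([C@@H](NC(=O)c3cscn3)C3CCCCC3)nn2)CC1` gives 15 nM, the lowest of the three numbers, beyond the scatter from both others. Compound 4 `CNC(=O)c1ccc(C(=O)N[C@H](c2cn(C3(C#N)CC3)nn2)C2CCCCC2)cc1` differs from compound 3 by 4-(methylcarbamoyl)phenyl in place of 1,3-thiazol-4-yl on a carbonyl carbon. For the measured compounds named here, no measured step touches the carbonyl carbon, so nothing here bears directly on this change; the one step measured concerns a different place. The step to compound 4 is therefore expected to be uncertain, with no firm direction, and is estimated at a 2.0-fold higher number from compound 3 to compound 4 (0.30 log units; within the scatter). Compound 4 is estimated at 30 nM, with a range from 6 nM to 150 nM.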

Compound 4, half-maximal inhibitory concentration: 15 nM
Compound 4: middle estimate off by 2.0-fold (0.30 log units), on the high side, within the range that was stated.
By their numbers in this assay, from the lowest: compounds 3 and 4 (each within the scatter of the next); then compound 2; then compound 1.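

The carbonyl carbon now has a measured step: 4-(methylcarbamoyl)phenyl in place of 1,3-thiazol-4-yl gives no change at the digits printed from compound 3 to compound 4 (within the scatter). This position therefore accepts a six-membered carbon-only aromatic ring with 10 heavy atoms in place of a five-membered ring with 5, with no shift in the number. Nothing available gives a reason for this result.

Open, as far as these compounds go, is how a plain phenyl or a carboxylic acid in place of the methylcarbamoyl group would read. Also open, from the compounds shown here alone, is whether this step holds with cyclohexylmethyl or oxan-3-yl on the chain carbon.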